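Swapping the Pendant Aryl: Cytotoxicity Expected for Compound 3

This account rests on a few compounds, and the source may have more. Where it says the series, first, only, none or still open, it means among the compounds named here.

Going by the values given here, compound 2 `Cc1cc(-c2c(C)cccc2C)cc(C)c1Nc1ccnc(Nc2ccc(C#N)cc2)n1` gives 2590 nM in an ADME assay on MT4 cells (Homo sapiens) for cytotoxicity, read by MTT assay, with a stated time of 4 days (a lower number here means that less compound is tolerated, a higher number that more compound is tolerated), the higher of the two numbers so far; its nearest neighbour, compound 1 `Cc1cc(-c2ccccc2F)cc(C)c1Nc1ccnc(Nc2ccc(C#N)cc2)n1`, gives 2120 nM. Compound 3 `COc1cccc(-c2cc(C)c(Nc3ccnc(Nc4ccc(C#N)cc4)n3)c(C)c2)c1` differs from compound 2 by 3-methoxyphenyl in place of 2,6-dimethylphenyl on an aromatic carbon, again an exchange of the pendant aryl ring. Among the compounds with values here, the only comparable step, a 1.2-fold higher number from compound 1 to compound 2 (0.09 log units; within the scatter), stayed within the scatter. Compound 3 is therefore expected to move no further than that in this assay, a step of a 1.1-fold lower number from compound 2 to compound 3 (0.03 log units; within the scatter). Compound 3 is estimated at 2400 nM, with a range from 1000 nM to 5500 nM.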

Compound 3, half-maximal cytotoxic concentration: 2990 nM
Estimate against measurement, compound 3: 1.2-fold (0.10 log units) below; low and high end bracket the measured number.
By their numbers in this assay, from the lowest: compounds 1, 2 and 3 (each within the scatter of the next).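

At this position, 3-methoxyphenyl, with 1 hydrogen-bond acceptor against 0 for 2,6-dimethylphenyl, leaves the number in this assay within the scatter (a 1.2-fold higher number from compound 2 to compound 3 (0.06 log units; within the scatter)). The widest gap among the three aryl groups shown also stays within the scatter (a 1.4-fold higher number from compound 1 to compound 3 (0.15 log units; within the scatter)), so compounds 1, 2 and 3 cannot be told apart here. No measurement bears on why this is so. Open, going by these compounds, is whether an amine or a carboxylic acid on the pendant ring would move the number beyond the scatter. So is whether a saturated ring in its place would.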